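This account rests on a few compounds, and the source may have more. Where it says the series, first, only, none or still open, it means among the compounds named here.

Measured compounds:
compound 1, `NC(=O)[C@H](CO)NCc1ccc(OCc2ccc(Cl)cc2)cc1`: 1100 nM
compound 2, `NC(=O)[C@H](CO)NCc1ccc(OCc2cccc(Cl)c2)cc1`: 43 nM
compound 3, `NC(=O)[C@H](CO)NCc1ccc(OCc2cccc(F)c2)cc1`: 140 nM

Among these three, compound 3 holds the second highest number in an assay on mitochondria for inhibition of Amine oxidase [flavin-containing] B (Rattus norvegicus); a lower number here means a stronger inhibitor, a higher number a weaker inhibitor: its nearest neighbour is compound 2, reached by a 3.3-fold higher number from compound 2 to compound 3 (0.51 log units; beyond the scatter), and the furthest is compound 1, from which compound 3 lies at a 7.9-fold lower number from compound 1 to compound 3 (0.90 log units; beyond the scatter).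

Compound 4, `NC(=O)[C@H](CO)NCc1ccc(OCc2ccccc2)cc1`, is the next one in line. It differs from compound 3 by hydrogen in place of fluoro on an aromatic carbon, so the benzyl group carries no halogen at all.

Of the measured steps, the one that bears most directly on this change is a 3.3-fold higher number from compound 2 to compound 3 (0.51 log units; beyond the scatter), where one halogen was replaced by a smaller one at the same aromatic carbon and the number rose by a modest amount. The steps of a 26-fold lower number from compound 1 to compound 2 (1.41 log units; beyond the scatter) and a 7.9-fold lower number from compound 1 to compound 3 (0.90 log units; beyond the scatter) concern where the halogen sits rather than whether it is present, so they speak to this change only indirectly. Taking the halogen away altogether is therefore expected to move the number further in the same direction as the chloro-to-fluoro step, by a modest step in this assay, and compound 4 is expected at a 2.5-fold higher number from compound 3 to compound 4 (0.40 log units; beyond the scatter) relative to compound 3, that is an estimated 350 nM with a range from 120 nM to 1000 nM.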

Compound 4, half-maximal inhibitory concentration: 410 nM
Compound 4: the middle estimate sits 1.2-fold (0.07 log units) below what was measured; measured number inside the range.
By their numbers in this assay, from the lowest: compound 2; then compound 3; then compound 4; then compound 1.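

Compound 4 gives the series its first benzyl group with no halogen, so the halogens in this assay can now be read against hydrogen: on the carbon meta to a large group, going from 3-fluorophenyl to phenyl gives a 2.9-fold higher number from compound 3 to compound 4 (0.47 log units; beyond the scatter), and going from 3-chlorophenyl to phenyl gives a 9.5-fold higher number from compound 2 to compound 4 (0.98 log units; beyond the scatter). Both halogens at this position therefore carry a lower number than hydrogen, and the chloro step is the larger of the two. The 4-chlorophenyl group goes against any general halogen benefit, since replacing its chloro with hydrogen gives a 2.7-fold lower number from compound 1 to compound 4 (0.43 log units; beyond the scatter), so the same change of chloro to hydrogen runs in opposite directions at the two positions. No measurement at hand explains these differences.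

The compounds shown leave open whether the order hydrogen, fluoro, chloro continues with bromo at the same carbon, or whether a methyl or methoxy group there would also give a lower number than hydrogen. They also leave open whether the 4-fluorophenyl group would share the higher number of the 4-chlorophenyl group or fall on the other side of phenyl.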